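Moving a Methyl Group Between Two Related Cores

A few compounds are considered here, and "the series" means these few. Any claim that something is new, unique, unknown or untested is made for them only; others in the source may bear on it.

Of the compounds shown here, three have been measured in a functional assay for inhibition, with Homo sapiens as the target; on this read-out higher numbers stand for weaker inhibition and lower numbers for stronger inhibition. Compound 2 `Cc1cccc(Nc2nccc(-c3ccccn3)n2)c1` gives 700 nM. Compound 1 `Cc1ccc(Nc2nccc(-c3ccccn3)n2)cc1C` gives 5900 nM. Compound 3 `c1ccc(Nc2nccc(-c3c[nH]c4ccccc34)n2)cc1`, built on a different core, gives 3000 nM. The difference between the cores of compound 2 and compound 3 is not broken down here. Compound 1 differs from compound 2 by one change, (methyl in place of hydrogen on an aromatic carbon), and that change gave an 8.4-fold higher number from compound 2 to compound 1 (0.93 log units; beyond the scatter).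

Compound 4 `Cc1cccc(Nc2nccc(-c3c[nH]c4ccccc34)n2)c1` is not yet measured. It differs from compound 3 by methyl in place of hydrogen on an aromatic carbon, the same kind of change that turned compound 2 into compound 1, but not the same: there the methyl entered ortho to a methyl group (1 heavy atom) and para to a large group, here it enters meta to a large group, on a ring that carries no other methyl. Among the measured compounds shown here, because the only comparable step, an 8.4-fold higher number from compound 2 to compound 1 (0.93 log units; beyond the scatter), was measured at a different place, compound 4 is expected to show a smaller shift, estimated as a 1.4-fold lower number from compound 3 to compound 4 (0.13 log units; within the scatter). The value of compound 4 in this assay is estimated at 2200 nM, between 700 nM and 7000 nM.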

Compound 4, half-maximal inhibitory concentration: 2200 nM
Compound 4: middle estimate and measured number agree at the digits printed; the range from low to high includes it.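

Turning phenyl into 3-methylphenyl gives a 1.4-fold lower number from compound 3 to compound 4 (0.13 log units; within the scatter) in this assay, so on this core a methyl meta to a large group leaves the number within the usual scatter. Set beside the earlier step, the same kind of change does not carry over in size from one core to the other: the same change on two cores in this assay, an 8.4-fold higher number (0.93 log units; beyond the scatter) from compound 2 to compound 1 and a 1.4-fold lower number (0.13 log units; within the scatter) from compound 3 to compound 4, 11-fold (1.06 log units) apart, beyond the scatter of two such steps. This does not show that the core alone decides the outcome: the two methyl groups also entered at different places, the ring of compound 2 already carried a methyl while the ring of compound 3 carried none, and a single pair on each core cannot separate these influences.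

Going by these compounds, it remains open what a second methyl on the ring of compound 4 would do, which would be the closer match to the step that gave compound 1. Also open, on these data alone, is whether another group at the place taken by the methyl in compound 4, such as an amine or a carboxylic acid, would give a larger step on this core.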